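From Trifluoromethyl to 2-Hydroxyethyl: A Step Without Footing

A few compounds are considered here, and "the series" means these few. Any claim that something is new, unique, unknown or untested is made for them only; others in the source may bear on it.

Of the compounds shown here, three built on one shared core have been tested in a functional assay on the whole organism for inhibition, with Rattus norvegicus as the target; on this read-out lower numbers stand for an effect already at smaller amounts and higher numbers for an effect only at larger amounts of compound. Compound 1 `CC1CC/C(=N\Nc2ccccc2Cl)c2ncc(C(=O)O)c(=O)n21` carries chloro; in this assay compound 1 gave only the limit > 1000 umol/kg. Compound 2 `CC1CC/C(=N\Nc2ccccc2Br)c2ncc(C(=O)O)c(=O)n21` carries bromo; in this assay compound 2 gave only the limit > 320 umol/kg. Compound 3 `CC1CC/C(=N\Nc2ccccc2C(F)(F)F)c2ncc(C(=O)O)c(=O)n21` carries trifluoromethyl; in this assay compound 3 also gave only the limit > 1000 umol/kg. Compound 3 thus sits at the limit of > 1000 umol/kg in this assay, at which 2 of the 3 values shown sit, and no ranking of the three is possible. The steps a step that the two limits leave unreadable from compound 1 to compound 2, a step that the two limits leave unreadable from compound 1 to compound 3 and a step that the two limits leave unreadable from compound 2 to compound 3 are all unreadable. Compound 4 `CC1CC/C(=N\Nc2ccccc2CCO)c2ncc(C(=O)O)c(=O)n21` differs from compound 3 by 2-hydroxyethyl in place of trifluoromethyl on an aromatic carbon. Going by the values given here, no measured step informs this change, so the expected step of a number no higher from compound 3 to compound 4 (the limit leaves the size open) is essentially none. Compound 4 is estimated at 1000 umol/kg, within 250 umol/kg to 4000 umol/kg, most likely again only a limit.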

Compound 4, dose for 50% inhibition: > 100 umol/kg
Compound 4 gave a limit, no number; the forecaster's own chance of this, stated with the estimate: 70%; the middle value lies beyond the limit too.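

Compound 4 gave only a limit, as did compound 1, compound 2 and compound 3, so no step among these four compounds can be read in this assay. Going by these compounds, how the four rank against one another stays open.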